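A Methoxyphenyl Group on the Amine Nitrogen

The source may report more compounds than this note shows. Statements on the series, on what has been measured and on what is new or still open speak of the compounds shown alone.

In an ADME assay (Homo sapiens) for cytotoxicity (a lower number here means that less compound is tolerated, a higher number that more compound is tolerated), compound 1, `Nc1nn2c(O)cc(CCl)nc2c1[N+](=O)[O-]`, gives > 50 ug/mL, which is a limit of the assay and not a number. Among the compounds with values here, compound 2, `NNCc1cc(O)n2nc(N)c([N+](=O)[O-])c2n1`, gives 42.6 ug/mL, the only actual number so far in this assay. Compound 3, `COc1ccc(NNCc2cc(O)n3nc(N)c([N+](=O)[O-])c3n2)cc1`, departs from compound 2 at one place: 4-methoxyphenyl in place of hydrogen on an amine nitrogen. This puts 4-methoxyphenyl in place of hydrogen on an amine nitrogen. Within the data shown here, only one measured step is available, an at least 1.1-fold lower number from compound 1 to compound 2 (0.06 log units; that floor lies within the scatter). It involves a different change at a different place, and it rests on a limit, so it gives little guidance on size or direction here. A step beyond the scatter is therefore not expected with any confidence. The expected change is a 1.4-fold lower number from compound 2 to compound 3 (0.15 log units; within the scatter), a small estimated shift that stays within the scatter. Compound 3 is estimated at 30 ug/mL, with an expected range of 14 ug/mL to 50 ug/mL.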

Compound 3, half-maximal cytotoxic concentration: 66.3 ug/mL
The estimate for compound 3 lay 2.2-fold (0.34 log units) below the measured number; measured number outside the range, above it.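

In this assay, the first substitution on this amine nitrogen gives a 1.6-fold higher number from compound 2 to compound 3 (0.19 log units; within the scatter). Within the data shown here, until now the nitrogen had carried only hydrogen, so the earlier compounds said nothing about what it would take. Compound 3 shows that 4-methoxyphenyl, with its 8 heavy atoms and six-membered aromatic ring, can sit at this place without a step beyond the scatter, and that the read-out remains a number and not a limit.

As far as these compounds go, whether a plain phenyl ring, a phenyl ring carrying chlorine, or a longer alkyl chain on the same nitrogen would also stay within the scatter remains open, as does any separate part played by the methoxy group. Compound 1 remains a limit of the assay and not a number, so its distance from the other compounds cannot be read: the limit of > 50 ug/mL in this assay, at which 1 of the 3 values shown sits.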